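Adding a bromo group to compound 2

The source may report more compounds than this note shows. Statements on the series, on what has been measured and on what is new or still open speak of the compounds shown alone.

- compound 1 `O=C(N/N=C/c1ccc(Br)cc1)Nc1ccc(Oc2ccnc3[nH]ccc23)c(F)c1` gives 930 nM in a functional assay on MCF7 cells (Homo sapiens) for antiproliferative activity, read by MTT assay, with a stated time of 72 h; a higher number here means a weaker inhibitor, a lower number a stronger inhibitor
- compound 2 `O=C(N/N=C/c1ccccc1)Nc1ccc(Oc2ccnc3[nH]ccc23)cc1` gives 1510 nM in this assay

For the measured compounds named here, these two values lie within the usual scatter of each other, so compound 2 stands level with the only other number available. Compound 3 `O=C(N/N=C/c1ccc(Br)cc1)Nc1ccc(Oc2ccnc3[nH]ccc23)cc1` has bromo in place of hydrogen on an aromatic carbon of compound 2 bromo in place of hydrogen on an aromatic carbon and so turns phenyl into 4-bromophenyl. Going by the values given here, no measured pair isolates this change. Compound 1 also carries 4-bromophenyl and gives 930 nM in this assay so only a small move toward a lower number is expected. The estimated step of a 1.4-fold lower number from compound 2 to compound 3 (0.14 log units; within the scatter) stays within the scatter. In this assay the estimated value for compound 3 is 1100 nM (expected range 450 nM to 2700 nM).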

Compound 3, half-maximal inhibitory concentration: "not active" (no number reported)
Compound 3: no number reported, and the estimate cannot be compared.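

For the compounds shown here, compound 3 is reported as "not active" with no number, so no step from compound 2 to compound 3 can be read. The compounds shown leave open how far 4-bromophenyl in place of phenyl alone shifts the number in this assay, and no evidence shown bears on this result.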